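This account rests on a few compounds, and the source may have more. Where it says the series, first, only, none or still open, it means among the compounds named here.

Measured so far in a functional assay on L1210 cells (Mus musculus) for inhibition, read by MTT assay, with a stated time of 72 h; on this read-out higher numbers stand for weaker inhibition and lower numbers for stronger inhibition:
- compound 1 (`COc1cc(NC(C)CCCNC(=O)Nc2cccc(F)c2)c2ncccc2c1`): 19000 nM
- compound 2 (`COc1cc(NC(C)CCCNC(=O)Nc2cccc(Cl)c2)c2ncccc2c1`): 17000 nM
- compound 3 (`COc1cc(NC(C)CCCNC(=O)NNC(=O)Nc2ccc(Cl)cc2)c2ncccc2c1`): 58000 nM

Compound 3 stands highest of the three, and so shows the weakest inhibition in this small set. Compound 4 (`COc1cc(NC(C)CCCNC(=O)Nc2cccc(O)c2)c2ncccc2c1`) is still unmeasured. The change is 3-hydroxyphenyl in place of ((4-chlorophenyl)carbamoyl)amino on an amide-type nitrogen, with 3-hydroxyphenyl in place of ((4-chlorophenyl)carbamoyl)amino on an amide-type nitrogen.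

The closest evidence is a 3.1-fold higher number from compound 1 to compound 3 (0.48 log units; beyond the scatter) and a 3.4-fold higher number from compound 2 to compound 3 (0.53 log units; beyond the scatter). In these steps, both modest and beyond the scatter, the leaving group of this change replaces 3-fluorophenyl and 3-chlorophenyl. Taken in reverse, they point to a modest fall in the number when a substituted phenyl group returns. For the measured compounds named here, the step of a 1.1-fold lower number from compound 1 to compound 2 (0.05 log units; within the scatter) lies within the scatter, but no hydroxy example has been measured, so the range stays wide.

In this assay the expected change is a 2.9-fold lower number from compound 3 to compound 4 (0.46 log units; beyond the scatter). For compound 4 the estimated value is 20000 nM, with an expected range of 8000 nM to 50000 nM.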

Compound 4, half-maximal inhibitory concentration: 25000 nM
For compound 4 the middle estimate is 1.3-fold (0.10 log units) below the measured one; the measured number falls inside the stated range.
By their numbers in this assay, from the lowest: compounds 2, 1 and 4 (each within the scatter of the next); then compound 3.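

In this assay, for the compounds shown here, the 3-hydroxyphenyl group adds a first non-halogen example at this amide-type nitrogen, and it cannot be separated from the halogen-bearing phenyl groups: hydroxy in place of chloro gives (a 1.5-fold higher number from compound 2 to compound 4 (0.17 log units; within the scatter)) and hydroxy in place of fluoro gives (a 1.3-fold higher number from compound 1 to compound 4 (0.12 log units; within the scatter)). The change away from ((4-chlorophenyl)carbamoyl)amino gives (a 2.3-fold lower number from compound 3 to compound 4 (0.37 log units; beyond the scatter)), so the lower number seen with the fluoro and chloro compounds also holds with hydroxy on the phenyl ring. No measurement shown here explains why these three substituents read alike.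

From the compounds shown here alone, whether an amine or a carboxylic acid on the same phenyl ring would stay level with compound 1, compound 2 and compound 4 remains open. Also open, going by these compounds, is whether a longer chain between the shared core and the urea would move the number at all.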